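Two Limits and One Analogue Still to Be Measured

A few compounds are considered here, and "the series" means these few. Any claim that something is new, unique, unknown or untested is made for them only; others in the source may bear on it.

Compound 1 `CCOc1ccccc1-n1nncc1CN1C(=O)C2(C(C#N)=C(N)Oc3c2c2nc4ccccc4nc2c2ccccc32)c2ccccc21`: > 50000 nM
Compound 2 `N#CC1=C(N)Oc2c(N)cc3nc4ccccc4nc3c2C12C(=O)N(Cc1cnnn1-c1cccc(C(F)(F)F)c1)c1ccccc12`: > 50000 nM

Both measured compounds share one core and differ only in the aryl group carried on the triazole nitrogen. In an ADME assay on HUVEC cells (Homo sapiens) for antiproliferative activity, read by MTT assay, with a stated time of 48 h (on this read-out lower numbers stand for stronger inhibition and higher numbers for weaker inhibition), compound 1 reaches no number at all; its value is a limit of the assay, > 50000 nM. Compound 2 fares the same way in this assay, where it also returns only a limit, > 50000 nM. For the measured compounds named here, compound 2 therefore stands at the edge of what the assay can report, and so does the only other value available (the limit of > 50000 nM in this assay, at which 2 of the 2 values shown sit).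

Compound 3 `N#CC1=C(N)Oc2c(N)cc3nc4ccccc4nc3c2C12C(=O)N(Cc1cnnn1-c1ccc(Cl)cc1[N+](=O)[O-])c1ccccc12` is built from compound 2 by one change, (4-chloro-2-nitrophenyl in place of 3-(trifluoromethyl)phenyl on an aromatic nitrogen). Going by the values given here, no step between measured compounds exists here, so the size of this step in this assay cannot be read from any precedent; with both measured values sitting at the limit, no change beyond the scatter can be discerned in either direction, and compound 3 is expected to stay at the limit as well because of the limit of > 50000 nM in this assay, at which 2 of the 2 values shown sit. Compound 3 is estimated at 50000 nM, within 20000 nM to 120000 nM. The step of a number no higher from compound 2 to compound 3 (the limit leaves the size open) is thus expected to be essentially nil.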

Compound 3, half-maximal inhibitory concentration: > 50000 nM
Compound 3: no number, only a limit; the forecaster's own chance of this, stated with the estimate: 85%; the middle value sits exactly at the limit.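

In this assay compound 3 also returns only a limit, > 50000 nM. For the compounds shown here, compound 2 sits at a limit too, and no step between compound 2 and compound 3 can be read. The compounds shown leave open whether the aryl group on the aromatic nitrogen alters this read-out at all, with no actual number available: the limit of > 50000 nM in this assay, at which 3 of the 3 values shown sit.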